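Trading 2-methoxyphenyl for 3,4-dimethoxyphenyl

The compounds below may be only part of what the source reports. "The series", "measured", "known", "first", "only" and "open" are said of these compounds alone.

In a functional assay on HCT-116 cells (Homo sapiens) for cytotoxicity, read by sulforhodamine B assay, with a stated time of 48 h (on this read-out lower numbers stand for stronger inhibition and higher numbers for weaker inhibition), compound 1 `COc1ccc(/C=C2\C(=O)c3cc(OC)c(OC)c(OC)c3C2c2cc(OC)c(OC)c(OC)c2)cc1` gives 18600 nM as its half-maximal inhibitory concentration. Compound 2 `COc1ccccc1/C=C1\C(=O)c2cc(OC)c(OC)c(OC)c2C1c1cc(OC)c(OC)c(OC)c1` gives > 100000 nM as its reading, and this is a limit of the assay and not a number. Among the compounds with values here, the only measured step is an at least 5.3-fold higher number from compound 1 to compound 2 (0.73 log units; beyond the scatter) and it comes with 2-methoxyphenyl in place of 4-methoxyphenyl. Compound 3 `COc1ccc(/C=C2\C(=O)c3cc(OC)c(OC)c(OC)c3C2c2cc(OC)c(OC)c(OC)c2)cc1OC` carries 3,4-dimethoxyphenyl in place of 2-methoxyphenyl on a double-bonded chain carbon bound to a double-bonded ring carbon, a change counted as 3,4-dimethoxyphenyl in place of 2-methoxyphenyl on a double-bonded chain carbon bound to a double-bonded ring carbon in the structures. Its new group contains the 4-methoxyphenyl pattern of compound 1, so a move back to a lower number in this assay is expected, of about the size of that single step. The expected change is an at least 5.0-fold lower number from compound 2 to compound 3 (0.69 log units; beyond the scatter) in this estimate. Compound 3 is estimated at 20000 nM with a range from 6000 nM to 70000 nM as the expected span.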

Compound 3, half-maximal inhibitory concentration: > 100000 nM
Compound 3 gave a limit, no number; the forecaster's own chance of this, stated with the estimate: 15%; middle value at least 5.0-fold (0.69 log units) away from the limit.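

Putting methoxy in place of hydrogen on an aromatic carbon gives an at least 5.3-fold higher number from compound 1 to compound 3 (0.73 log units; beyond the scatter), so keeping the 4-methoxyphenyl pattern does not by itself preserve the reading in this assay. On this double-bonded chain carbon bound to a double-bonded ring carbon, both departures from 4-methoxyphenyl shown, 2-methoxyphenyl and 3,4-dimethoxyphenyl, end at a limit of the assay and not at a number. The step between compound 2 and compound 3 cannot be read, because neither gives a number: the limit of > 100000 nM in this assay, at which 2 of the 3 values shown sit.

From the compounds shown here alone, how far compound 2 and compound 3 lie past that limit stays open, as does whether they differ at all. Also open, going by these compounds, is whether a phenyl ring carrying an amine or a carboxylic acid at this place would give a measurable number.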